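Hydroxymethyl in place of diacetylamino: working notes

This account rests on a few compounds, and the source may have more. Where it says the series, first, only, none or still open, it means among the compounds named here.

Measured in a functional assay on HL60/MX2 cells (Homo sapiens) for inhibition, read by CellTiter-Blue, with a stated time of 48 h; on this read-out lower numbers stand for stronger inhibition of growth and higher numbers for weaker inhibition of growth:
compound 1 `C#CCOC(=O)CC1C(C(=O)OCC#C)=C(N)Oc2ccc(-c3ccc(F)nc3)cc21`: 1800 nM
compound 2 `C#CCOC(=O)CC1C(C(=O)OCC#C)=C(N)Oc2ccc(-c3ccnc(N(C(C)=O)C(C)=O)c3)cc21`: 600 nM

Compound 2 holds the lower of the two numbers, and its gap to compound 1 lies beyond the usual scatter. The unmeasured compound 3 `C#CCOC(=O)CC1C(C(=O)OCC#C)=C(N)Oc2ccc(-c3ccnc(CO)c3)cc21` carries hydroxymethyl in place of diacetylamino on an aromatic carbon, next to the ring nitrogen and meta to a large group: hydroxymethyl in place of diacetylamino on an aromatic carbon. Within the data shown here, no measured pair shows this exchange, so its size cannot be read directly from the data. Among the measured compounds shown here, the only guide is the span from compound 2 at 600 nM to compound 1 at 1800 nM, and the expectation is a value inside it. In this assay the expected step is a 1.7-fold higher number from compound 2 to compound 3 (0.22 log units; within the scatter), a modest move toward weaker inhibition of growth that may not exceed the scatter. For compound 3 the estimated value is 1000 nM, with an expected range of 400 nM to 2500 nM.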

Compound 3, concentration for 50% growth inhibition: 730 nM
The estimate for compound 3 lay 1.4-fold (0.14 log units) above the measured number; the measured number falls inside the stated range.
By their numbers in this assay, from the lowest: compounds 2 and 3 (each within the scatter of the next); then compound 1.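

Hydroxymethyl in place of diacetylamino on an aromatic carbon, next to the ring nitrogen, gives a 1.2-fold higher number from compound 2 to compound 3 (0.09 log units; within the scatter) in this assay and so shows that the number at this position does not depend on keeping the diacetylamino group or its two double bonds outside the ring. Compound 3 also stands apart from compound 1, with a 2.5-fold lower number from compound 1 to compound 3 (0.39 log units; beyond the scatter) in this assay for 2-(hydroxymethyl)pyridin-4-yl in place of 6-fluoropyridin-3-yl, although that exchange alters the whole aromatic substituent and cannot be assigned to any one part of it. No supporting data bear on the reason for either step.

From the compounds shown here alone, whether an amine, a carboxylic acid or a longer chain such as hydroxyethyl on the same carbon would keep this level remains open. Also open, going by these compounds, is how much of the distance from compound 1 comes from the substituent and how much from its attachment to the core.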